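The source may report more compounds than this note shows. Statements on the series, on what has been measured and on what is new or still open speak of the compounds shown alone.

The measured compounds and their values:
compound 1, `CCCCn1ccc2cc(/C(C)=C/C(=O)Nc3ccccc3OCCCC(=O)O)ccc21`: 43 nM in an assay on Prostate gland for inhibition of steroid 5-alpha-reductase (Rattus norvegicus); a higher number here means a weaker inhibitor, a lower number a stronger inhibitor
compound 2, `CCCCCn1ccc2cc(/C(C)=C/C(=O)Nc3ccccc3OCCCC(=O)O)ccc21`: 23 nM
compound 3, `CCCCC(C)n1ccc2cc(/C(C)=C/C(=O)Nc3ccccc3OCCCC(=O)O)ccc21`: 6 nM

Among these three, compound 1 gives the highest number in this assay. Its nearest neighbour is compound 2, reached by a 1.9-fold lower number from compound 1 to compound 2 (0.27 log units; within the scatter); its furthest is compound 3, reached by a 7.2-fold lower number from compound 1 to compound 3 (0.86 log units; beyond the scatter). Between those two lies a 3.8-fold lower number from compound 2 to compound 3 (0.58 log units; beyond the scatter). Every measured step enlarges the group on the aromatic nitrogen of the shared core, and each of the two steps that go beyond the scatter lowers the number.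

Compound 4, `C/C(=C\C(=O)Nc1ccccc1OCCCC(=O)O)c1ccc2c(ccn2Cc2ccc(C(F)(F)F)cc2)c1`, is not yet measured. Against compound 1 it differs as follows: 4-(trifluoromethyl)phenyl in place of propyl on a saturated chain carbon bound to an aromatic nitrogen. Among the measured compounds shown here, no measured step exchanges a chain for a ring at this place, so the only bearing comes from the chain enlargements on the aromatic nitrogen, which lowered the number or stayed within the scatter. A lowering of modest size is therefore expected, though with wide uncertainty. The entering group is larger than any change that was measured. Compound 4 is expected to give 15 nM in this assay, between 4 nM and 60 nM, an estimated step of a 2.9-fold lower number from compound 1 to compound 4 (0.46 log units; beyond the scatter).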

Compound 4, half-maximal inhibitory concentration: 300 nM
Beside the measured number, compound 4's estimate is 20-fold (1.30 log units) below it; measured number above the stated range.
By their numbers in this assay, from the lowest: compound 3; then compounds 2 and 1 (each within the scatter of the next); then compound 4.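

At the aromatic nitrogen of the shared core, every earlier enlargement lowered the number in this assay or stayed within the scatter, whereas 4-(trifluoromethyl)benzyl in place of butyl gives a 7.0-fold higher number from compound 1 to compound 4 (0.84 log units; beyond the scatter). The gap widens against the other chains, with a 13-fold higher number from compound 2 to compound 4 (1.12 log units; beyond the scatter) and a 50-fold higher number from compound 3 to compound 4 (1.70 log units; beyond the scatter), so adding atoms at this place does not by itself lower the number, and compound 4 stands against the trend of the three chain compounds. Nothing at hand gives a reason for this reversal.

From the compounds shown here alone, whether the rise belongs to the aromatic ring itself or to its trifluoromethyl group stays open, and a plain benzyl, a 4-methoxybenzyl or a cyclohexylmethyl group on the aromatic nitrogen would help to separate the two. Also open, going by these compounds, is whether the methyl branch that accompanies the lowest number, in compound 3, would lower the number on a ring-bearing group such as 1-phenylethyl, and how far a longer branched chain such as 1-methylhexyl would carry that lowering.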